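Swapping trifluoromethyl for sulfamoyl on a thienopyrimidine antagonist

The source may report more compounds than this note shows. Statements on the series, on what has been measured and on what is new or still open speak of the compounds shown alone.

Compound 1, `FC(F)(F)c1ccc(Nc2ncnc3sc(Nc4c(Cl)cccc4Cl)nc23)cc1` — 3 nM
Compound 2, `CSc1ccccc1Nc1nc2c(Nc3ccc(C(F)(F)F)cc3)ncnc2s1` — 26 nM
Compound 3, `CS(=O)(=O)c1ccccc1Nc1nc2c(Nc3ccc(C(F)(F)F)cc3)ncnc2s1` — 221 nM

All three were tested in a functional assay on HEK293 cells for antagonist activity at transient receptor potential cation channel subfamily V member 1 (Rattus norvegicus), read by calcium flux; a lower number here means a stronger inhibitor, a higher number a weaker inhibitor. Compound 1 gives the lowest number of the three: the step of an 8.7-fold higher number from compound 1 to compound 2 (0.94 log units; beyond the scatter) and the step of a 74-fold higher number from compound 1 to compound 3 (1.87 log units; beyond the scatter) both lead to weaker inhibitors, and the step of an 8.5-fold higher number from compound 2 to compound 3 (0.93 log units; beyond the scatter) lies between the two variants. Every one of these steps changes the group on the other nitrogen of the shared core, while the trifluoromethylphenyl part stays the same.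

Compound 4, `NS(=O)(=O)c1ccc(Nc2ncnc3sc(Nc4c(Cl)cccc4Cl)nc23)cc1`, is not yet measured. It differs from compound 1 by the following change: sulfamoyl in place of trifluoromethyl on an aromatic carbon. No measured step touches this position, so nothing shown directly predicts its effect. The measured steps only show that the shared core tolerates some variation without losing all activity. The number for compound 4 in this assay is therefore expected to rise somewhat, by a 10-fold higher number from compound 1 to compound 4 (1.00 log units; beyond the scatter), with wide uncertainty. Compound 4 is estimated at 30 nM, ranging from 5 nM to 200 nM.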

Compound 4, half-maximal inhibitory concentration: 590 nM
Compound 4: middle estimate off by 20-fold (1.29 log units), on the low side; measured number outside the range, above it.
By their numbers in this assay, from the lowest: compound 1; then compound 2; then compound 3; then compound 4.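

In this assay, the place para to a large group proves highly sensitive: sulfamoyl in place of trifluoromethyl brings a 200-fold higher number from compound 1 to compound 4 (2.29 log units; beyond the scatter), a step printed as large. The two groups match in heavy-atom count, but sulfamoyl carries a hydrogen-bond donor and hydrogen-bond acceptors that trifluoromethyl lacks, so matching that count alone does not keep the activity here. The earlier steps shown here changed only the group on the other nitrogen, the biggest being a 74-fold higher number from compound 1 to compound 3 (1.87 log units; beyond the scatter), and this result shows that the trifluoromethylphenyl side can also cost a large share of the activity.

Nothing available explains why sulfamoyl gives this loss. Going by these compounds, whether a nitrile, a chlorine atom or a tert-butyl group at this place would stay close to compound 1 remains open.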